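A few compounds are considered here, and "the series" means these few. Any claim that something is new, unique, unknown or untested is made for them only; others in the source may bear on it.

Measured so far:
compound 1, `COc1cc(-c2cc(/C=C/C(=O)c3ccc(Cl)c(Cl)c3)[nH]n2)cc(OC)c1OC`, 6990 nM
compound 2, `COc1ccc(-c2cc(/C=C/C(=O)c3cc(OC)c(OC)c(OC)c3)[nH]n2)cc1OC`, 1590 nM

Both numbers come from a functional assay on OVCAR-3 cells (Homo sapiens) for inhibition, read by sulforhodamine B assay, with a stated time of 48 h; a lower number here means a stronger inhibitor of growth, a higher number a weaker inhibitor of growth. Of the two, compound 1 stands at the higher number, which makes it the weaker inhibitor of growth of the pair, and its gap to compound 2 lies beyond the usual scatter. Compound 2 carries methoxy-bearing rings at both ends of the shared core, whereas compound 1 carries a chlorine-bearing ring on its carbonyl side.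

Compound 3, `COc1ccc(C(=O)/C=C/c2cc(-c3cc(OC)c(OC)c(OC)c3)n[nH]2)cc1OC`, has not yet been measured in this assay. It differs from compound 1 in one place: 3,4-dimethoxyphenyl in place of 3,4-dichlorophenyl on a carbonyl carbon. For the measured compounds named here, the one comparison in hand, compound 2 at 1590 nM against compound 1 at 6990 nM, has the methoxy-bearing ring at the carbonyl sitting at the lower number. On that basis compound 3 is expected to move in the same direction, with a step of a 2.8-fold lower number from compound 1 to compound 3 (0.45 log units; beyond the scatter), beyond the scatter but not large. The estimate for compound 3 is 2500 nM, within a range from 800 nM to 8000 nM.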

Compound 3, concentration for 50% growth inhibition: 1680 nM
Beside the measured number, compound 3's estimate is 1.5-fold (0.17 log units) above it, within the range that was stated.
By their numbers in this assay, from the lowest: compounds 2 and 3 (each within the scatter of the next); then compound 1.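

Compound 1 and compound 3 differ in one place only, so this pair isolates the group on the carbonyl carbon, which compound 1 and compound 2 could not do, as they differ in more than one place. In this assay, 3,4-dimethoxyphenyl in place of 3,4-dichlorophenyl gives a 4.2-fold lower number from compound 1 to compound 3 (0.62 log units; beyond the scatter), a modest change but one beyond the usual scatter, so this position does respond to the choice of ring substituents. Nothing measured here explains the size or direction of this step.

Still open, on these data alone, is whether both methoxy groups are needed, or whether a single methoxy or a single chlorine on the ring would give a similar number. Also open, as far as these compounds go, is how the number would respond to an amine or a carboxylic acid on this ring.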